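Mirror-image change at one centre of compound 2

The source may hold more compounds than are shown below. What is called first, only, known or untested is meant among the compounds shown, and "the series" means these compounds.

Values in an ADME assay on microsomes from liver (Homo sapiens) for metabolic stability, read by LC-MS, with a stated time of 10 min, tested at 0.5 uM; on this read-out lower numbers stand for a less stable compound and higher numbers for a more stable compound:
- compound 1 `c1ccc2c(c1)CN[C@@H](CN(CC1CCNCC1)[C@H]1CCCc3cccnc31)C2`: 86%
- compound 2 `c1ccc2c(c1)CN[C@H](CN(CCCN1CCNCC1)[C@H]1CCCc3cccnc31)C2`: 99%

Compound 2 stands higher of the two at 99% and compound 1 gives 86% with a gap beyond the usual scatter of repeated measurements. These two compounds do not differ in just one place, so their gap cannot be pinned on any single structural feature.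

The next compound to be measured is compound 3 `c1ccc2c(c1)CN[C@@H](CN(CCCN1CCNCC1)[C@H]1CCCc3cccnc31)C2` and its difference from compound 2 is one of spatial arrangement alone: the two compounds have the same atoms and bonds and differ only in configuration as drawn: 1 of 2 stereo elements differ; a stereocentre at a saturated ring carbon is drawn S in compound 2 and R in compound 3 (a stereocentre at a saturated ring carbon is drawn S in compound 2 and R in compound 3).

For the measured compounds named here, no measured pair shows what such a switch does in this assay and so this expectation rests on little. The most likely outcome is no shift beyond the scatter. Any shift is expected to be downward, as compound 2 at 99% already sits close to the top of the scale. The expected move is a number 6 percentage points lower from compound 2 to compound 3 (within the scatter) and so would stay within the usual scatter. The estimated value for compound 3 is 93% with 80% to 100% as its expected range.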

Compound 3, percent of the compound remaining: 100%
Estimate against measurement, compound 3: 7 percentage points below; the range from low to high includes it.
By their numbers in this assay, from the lowest: compound 1; then compounds 2 and 3 (each within the scatter of the next).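

The mirror-image switch at the saturated ring carbon gives a number 1 percentage points higher from compound 2 to compound 3 (within the scatter), so in this assay the drawn configuration at this centre makes no difference that can be told from the scatter, and the comparison isolates that centre alone: the fact that compounds 2 and 3 differ only in the configuration as drawn

For the compounds shown here, the result also allows the first comparison in which the side chain changes in one place only: 2-(piperazin-1-yl)ethyl in place of piperidin-4-yl on a saturated chain carbon bound to an amine nitrogen gives a number 14 percentage points higher from compound 1 to compound 3 (beyond the scatter), a modest step beyond the scatter. With compound 3 at 100%, this read-out has no room to show any further gain, so it can separate compounds only when a change lowers the number.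

The compounds shown leave open whether the same switch would stay as silent with the piperidin-4-yl side chain of compound 1, and what a mirror-image change at the other stereocentre would do. They also leave open whether the step from compound 1 to compound 3 would hold if a morpholine ring took the place of the piperazine, or if the chain carrying it were longer.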